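Thiophene in place of phenyl on the shared core

This account rests on a few compounds, and the source may have more. Where it says the series, first, only, none or still open, it means among the compounds named here.

Compound 3 `C=C(Br)C(=O)Nc1cccc(-c2cn3nc(-c4ccccc4)sc3n2)c1` is the point of reference. In a functional assay on CCRF-CEM cells (Homo sapiens) for inhibition, read by cell counting, with a stated time of 3 days (a lower number here means a stronger inhibitor, a higher number a weaker inhibitor), compound 3 gives 960 nM, the lowest of the two numbers recorded so far. Within the data shown here, its nearest neighbour is compound 1 `C=C(Br)C(=O)Nc1cccc(-c2cn3nc(-c4ccc(CC)cc4)sc3n2)c1`, which in this assay gives 3400 nM; the single measured step, a 3.5-fold lower number from compound 1 to compound 3 (0.55 log units; beyond the scatter), is the removal of an ethyl group from the phenyl and is modest in size. Compound 2 `CCOc1ccc(-c2nn3cc(-c4cccc(N)c4)nc3s2)cc1` returns only a limit of the assay in this assay, namely > 250000 nM. That entry is the limit of > 250000 nM in this assay, at which 1 of the 3 values shown sits, and carries no number that can be compared.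

Compound 4 `C=C(Br)C(=O)Nc1cccc(-c2cn3nc(-c4cccs4)sc3n2)c1` differs from compound 3 in one place: thiophen-2-yl in place of phenyl on an aromatic carbon. Among the measured compounds shown here, no measured step addresses an exchange of the ring itself; the one recorded step, a 3.5-fold lower number from compound 1 to compound 3 (0.55 log units; beyond the scatter), alters a substituent on the phenyl and leaves the ring in place, so it gives little guidance on the size or direction here. For the measured compounds named here, with no direct precedent, the step from compound 3 to compound 4 is expected to be a 1.3-fold higher number from compound 3 to compound 4 (0.10 log units; within the scatter), that is, no change beyond the scatter. The estimate for compound 4 in this assay is therefore 1200 nM, with a range of 400 nM to 4000 nM.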

Compound 4, half-maximal inhibitory concentration: 410 nM
Compound 4: middle estimate off by 2.9-fold (0.47 log units), on the high side, and the stated range covers the measured number.
By their numbers in this assay, from the lowest: compound 4; then compound 3; then compound 1. At a limit, above all of these: compound 2.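

In this assay the ring on this aromatic carbon of the shared core can itself be exchanged without loss, and thiophen-2-yl in place of phenyl gives a 2.3-fold lower number from compound 3 to compound 4 (0.37 log units; beyond the scatter). Set against 4-ethylphenyl, the same ring gives an 8.3-fold lower number from compound 1 to compound 4 (0.92 log units; beyond the scatter), so among the three compounds that differ only at this place, the number falls in the order 4-ethylphenyl, phenyl, thiophen-2-yl, and none of the three goes against that order. Among these compounds, nothing measured so far bears on why the five-membered ring with its sulfur gives a lower number than phenyl at this place.

Still open, from the compounds shown here alone, is whether the lower number follows from the smaller ring or from the sulfur, a question that furan-2-yl, thiophen-3-yl or pyridin-2-yl at the same place would help to separate. Also open is how far the thiophen-2-yl ring tolerates substitution, for instance by a methyl group, a chlorine atom, an amine or a carboxylic acid, given that on the phenyl ring the one substituent shown, ethyl, goes with a higher number.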